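The source may hold more compounds than are shown below. What is called first, only, known or untested is meant among the compounds shown, and "the series" means these compounds.

The set comprises three measured compounds and one not yet measured. Compound 1 `O=C1CC[C@@H](NC(=O)OCc2ccccc2)C(=O)N1`, compound 2 `O=C1C[C@@H](NC(=O)OCc2ccccc2)C(=O)N1` and compound 3 `CN1C(=O)C[C@@H](NC(=O)OCc2ccccc2)C1=O` were all characterised in a functional assay on the whole organism with Mus musculus as the target; on this read-out higher numbers stand for an effect only at larger amounts of compound and lower numbers for an effect already at smaller amounts. In this assay compound 1 gives 56.3 mg/kg. Compound 2 gives 125 mg/kg in this assay, the highest of the three numbers; the nearest to it is compound 1, the furthest is compound 3, which gives 52.5 mg/kg in this assay. Going by the values given here, the one measured step between neighbours is a 2.4-fold lower number from compound 2 to compound 3 (0.38 log units; beyond the scatter). Compound 4 `O=C1C[C@H](NC(=O)OCc2ccccc2)C(=O)N1` is the counterpart of compound 2: the two compounds have the same atoms and bonds and differ only in configuration as drawn: 1 of 1 stereo elements differ; a stereocentre at a saturated ring carbon is drawn R in compound 2 and S in compound 4. Among the compounds with values here, none of the measured steps concerns a change in configuration alone, so the single comparison in hand, the step from compound 2 to compound 3, does not bear on the change leading to compound 4. The expectation for compound 4 in this assay therefore rests on compound 2 alone, with 125 mg/kg as the anchor, and no step beyond the scatter is predicted in either direction, although a real difference between the two configurations cannot be excluded, which widens the range. The expected change is a 1.1-fold lower number from compound 2 to compound 4 (0.06 log units; within the scatter). Compound 4 is estimated at 110 mg/kg, with a range from 35 mg/kg to 350 mg/kg.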

Compound 4, dose for half-maximal effect: 103 mg/kg
Compound 4: the middle estimate sits 1.1-fold (0.03 log units) above what was measured, within the range that was stated.
By their numbers in this assay, from the lowest: compounds 3, 1, 4 and 2 (each within the scatter of the next, the first and the last beyond it).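

In this assay, changing the stereocentre at a saturated ring carbon from R to S gives a 1.2-fold lower number from compound 2 to compound 4 (0.08 log units; within the scatter), so at this position the configuration as drawn produces no difference that this read-out can separate from the scatter. The earlier step, a 2.4-fold lower number from compound 2 to compound 3 (0.38 log units; beyond the scatter), concerned methyl in place of hydrogen on an amide-type nitrogen in a ring and gave no information about configuration. The new comparison can be read as a test of configuration alone, because nothing else in the structures changes: the fact that compounds 2 and 4 differ only in the configuration as drawn

The compounds shown leave open whether configuration would matter as little in the presence of the methyl group of compound 3 or in the core of compound 1. They also leave open how the read-out would respond if an amine or a carboxylic acid stood in place of the benzyloxycarbonyl group on the shared core.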